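The compounds below may be only part of what the source reports. "The series", "measured", "known", "first", "only" and "open" are said of these compounds alone.

Of the compounds shown here, three sharing one core have been measured in a functional assay on SW-620 cells (Homo sapiens) for inhibition, read by MTT assay, with a stated time of 72 h; a lower number here means a stronger inhibitor, a higher number a weaker inhibitor. Compound 1 `COc1cc(NC(C)CCCNC(=O)Nc2ccc(Br)cc2)c2ncccc2c1` gives 23000 nM, compound 2 `COc1cc(NC(C)CCCNC(=O)Nc2ccc(C(F)(F)F)cc2)c2ncccc2c1` gives 22000 nM, and compound 3 `COc1cc(NC(C)CCCNC(=O)Nc2cccc(C(F)(F)F)c2)c2ncccc2c1` gives 22000 nM. Compound 3 therefore stands level with compound 2 and within the usual scatter of compound 1.

Compound 4 `COc1cc(NC(C)CCCNC(=O)NNC(=O)Nc2cccc(Cl)c2)c2ncccc2c1` has not yet been measured. Its difference from compound 3 is this: ((3-chlorophenyl)carbamoyl)amino in place of 3-(trifluoromethyl)phenyl on an amide-type nitrogen. In short, ((3-chlorophenyl)carbamoyl)amino replaces 3-(trifluoromethyl)phenyl on an amide-type nitrogen.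

The measured steps bear on this change only in part, since they merely exchange groups on the aromatic ring. They are a 1.0-fold lower number from compound 1 to compound 2 (0.02 log units; within the scatter), a 1.0-fold lower number from compound 1 to compound 3 (0.02 log units; within the scatter) and no change at the digits printed from compound 2 to compound 3 (within the scatter), all of them small. None adds the carbamoyl-amino unit, so the guidance is weak and the uncertainty wide. No shift beyond the scatter is expected in this assay, in either direction. The expected size of the change is a 1.2-fold lower number from compound 3 to compound 4 (0.09 log units; within the scatter). The estimated value for compound 4 is 18000 nM, with an expected range from 6000 nM to 50000 nM.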

Compound 4, half-maximal inhibitory concentration: 25000 nM
For compound 4 the middle estimate is 1.4-fold (0.14 log units) below the measured one; measured number inside the range.
By their numbers in this assay, from the lowest: compounds 2, 3, 1 and 4 (each within the scatter of the next).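

In this assay, among the compounds shown here, the earlier compounds only exchanged groups on the aromatic ring, while compound 4 places ((3-chlorophenyl)carbamoyl)amino on the amide-type nitrogen, bringing in a carbonyl and hydrogen-bond donors that 3-(trifluoromethyl)phenyl lacks. Even so, the result is a 1.1-fold higher number from compound 3 to compound 4 (0.06 log units; within the scatter), along with a 1.1-fold higher number from compound 2 to compound 4 (0.06 log units; within the scatter) and a 1.1-fold higher number from compound 1 to compound 4 (0.04 log units; within the scatter), so this substantial change at this position produces no shift beyond the scatter. Nothing measured here accounts for this absence of a shift.

For the compounds shown here, the single step swaps the ring substituent and adds the carbamoyl-amino unit together, so the contribution of each stays unseparated. Also open, as far as these compounds go, is whether an amine or a carboxylic acid on the aromatic ring, or a longer chain at this nitrogen, would move the number beyond the scatter.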